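Chloro on the anilide ring of compound 1

The source may report more compounds than this note shows. Statements on the series, on what has been measured and on what is new or still open speak of the compounds shown alone.

The shared core of this small set is a piperidinone bearing two benzylidene arms, linked through a fumaramide to an aryl amine. In a functional assay on L1210 cells (Mus musculus) for cytotoxicity (on this read-out lower numbers stand for stronger inhibition and higher numbers for weaker inhibition), compound 1 `O=C(/C=C/C(=O)N1C/C(=C\c2ccccc2)C(=O)/C(=C/c2ccccc2)C1)Nc1ccccc1` gives 3600 nM, the highest of the three numbers recorded. Compound 2 `Cc1cccc(C)c1NC(=O)/C=C/C(=O)N1C/C(=C\c2ccc([N+](=O)[O-])cc2)C(=O)/C(=C/c2ccc([N+](=O)[O-])cc2)C1`, which carries nitro groups on both arms and a 2,6-dimethylphenyl on the amide nitrogen, gives 690 nM in this assay. Compound 3 `COc1ccc(NC(=O)/C=C/C(=O)N2C/C(=C\c3ccc([N+](=O)[O-])cc3)C(=O)/C(=C/c3ccc([N+](=O)[O-])cc3)C2)cc1` gives 2900 nM in this assay, and this value sits within the scatter of compound 1. Among the measured compounds shown here, the one step that can be computed, a 4.2-fold higher number from compound 2 to compound 3 (0.62 log units; beyond the scatter), concerns the amide-side aryl group, the same region that changes here, but it swaps one substituted ring for another and does not test a chloro for a hydrogen.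

Compound 4 `O=C(/C=C/C(=O)N1C/C(=C\c2ccccc2)C(=O)/C(=C/c2ccccc2)C1)Nc1ccc(Cl)cc1` differs from compound 1 by chloro in place of hydrogen on an aromatic carbon. For the measured compounds named here, no measured pair shows this exact change, so the expectation rests on the weak sensitivity of the amide-side ring seen so far. Compound 4 is therefore expected to give roughly 3000 nM in this assay, within a range from 1200 nM to 8000 nM. This estimate means a step of a 1.2-fold lower number from compound 1 to compound 4 (0.08 log units; within the scatter), expected to stay within the scatter.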

Compound 4, half-maximal inhibitory concentration: 7800 nM
Compound 4: the middle estimate sits 2.6-fold (0.41 log units) below what was measured; measured number inside the range.
By their numbers in this assay, from the lowest: compound 2; then compounds 3 and 1 (each within the scatter of the next); then compound 4.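

On the phenyl ring of the phenylcarbamoyl group, with the benzylidene arms left as they are, a single chloro para to a large group gives a 2.2-fold higher number from compound 1 to compound 4 (0.34 log units; beyond the scatter) in this assay. The earlier step on this side of the molecule exchanged one substituted ring for another on nitro-bearing arms, whereas this one adds a single atom to a bare ring and shows that the position responds even to that small change, with the number moving modestly towards weaker inhibition. Nothing in the available data accounts for this rise.

Among the compounds shown here, it remains open whether chloro in place of hydrogen would move the number the same way on a compound with nitro groups on both arms, since the only amide-side step on such arms involves other rings. On these data alone, it also remains open whether a different group at this place, such as fluoro, an amine or a carboxylic acid, would raise the number as chloro does or lower it.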